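This account rests on a few compounds, and the source may have more. Where it says the series, first, only, none or still open, it means among the compounds named here.

In a functional assay on A549 cells (Homo sapiens) for inhibition, read by XTT assay, with a stated time of 48 h (a lower number here means a stronger inhibitor, a higher number a weaker inhibitor), three compounds of a shared core have been measured, and a fourth awaits its number. Compound 1 `COc1ccc(C(=O)/C(=C/c2ccc(Cl)cc2Cl)CCOC(C)=O)cc1` gives 69200 nM. Compound 3 `COc1ccc(C(=O)/C(=C/c2ccc(Cl)cc2Cl)CC(C)C)cc1` gives 80300 nM. For compound 2 `COc1ccc(C(=O)/C(=C/c2ccc([N+](=O)[O-])cc2)CCOC(C)=O)cc1` the assay reports only a limit, > 100000 nM, and not a number.

Two single changes link these compounds. From compound 1 to compound 2 the core carries 4-nitrophenyl in place of 2,4-dichlorophenyl on a double-bonded chain carbon bound to a double-bonded chain carbon, and the number rises an at least 1.4-fold higher number from compound 1 to compound 2 (0.15 log units; that floor lies within the scatter); since compound 2 sits at the limit of > 100000 nM in this assay, at which 1 of the 3 values shown sits, only the floor of that step is known. From compound 1 to compound 3 the change is isopropyl in place of acetoxymethyl on a saturated chain carbon bound to a double-bonded chain carbon, and the step is a 1.2-fold higher number from compound 1 to compound 3 (0.06 log units; within the scatter), so compounds 1 and 3 cannot be told apart in this assay.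

The unmeasured compound 4 `COc1ccc(C(=O)/C(=C/c2ccc([N+](=O)[O-])cc2)CC(C)C)cc1` stands to compound 2 as compound 3 stands to compound 1: the difference is isopropyl in place of acetoxymethyl on a saturated chain carbon bound to a double-bonded chain carbon, made at the same place, so it is the same change seen a second time. When that change was made from compound 1 to compound 3 it left the number essentially where it was, and compound 2 already sits at the limit of this assay. Compound 4 is therefore expected to move by about a step that the limit leaves unreadable from compound 2 to compound 4 from compound 2, a step no larger than the earlier one. Compound 4 is estimated at 130000 nM, between 60000 nM and 300000 nM, and it may well again be reported only as a limit.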

Compound 4, half-maximal inhibitory concentration: > 100000 nM
Compound 4 ended at the assay's limit (the forecaster's own chance of this, stated with the estimate: 70%); the middle value lies beyond the limit too.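

In this assay compound 4 gives > 100000 nM and this is a limit of the assay, not a number. Compound 2 also carries only a limit, so no step can be read between compound 2 and compound 4. The compounds shown leave open whether isopropyl in place of acetoxymethyl shifts the number at all when the 4-nitrophenyl group is present, and how far either compound lies past the limit.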